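The compounds below may be only part of what the source reports. "The series", "measured", "known", "first", "only" and "open" are said of these compounds alone.

Measured so far:
compound 1 `Cc1ccnc(/C(N)=N/NC(=S)N2CCSCC2)c1`, 40.4%
compound 2 `N/C(=N\NC(=S)N1CCSCC1)c1ccccn1`, 39.7%
compound 3 `N/C(=N\NC(=S)N1CCCCCC1)c1ccc(F)cn1`, 65.1%

In a functional assay on HeLa cells (Homo sapiens) for cytotoxicity, read by MTT assay, with a stated time of 72 h, tested at 3 uM (a higher number here means more inhibition of growth at the concentration tested, a lower number less inhibition of growth), compound 1 stands second highest of the three numbers, with compound 2 lying within the scatter of it and compound 3 the furthest away, at a higher number. Going by the values given here, the only step between compounds that differ in one place, a number 0.7 percentage points lower from compound 1 to compound 2 (within the scatter), concerns a change on the aromatic ring and not the group on the thiocarbonyl carbon. Compound 4 `Cc1ccnc(/C(N)=N/NC(=S)N2CCCCC2)c1` carries piperidin-1-yl in place of thiomorpholin-4-yl on a thiocarbonyl carbon. Among the compounds with values here, no measured step bears on this exchange, and compound 3 differs from compound 1 in more than one place, so its higher number cannot be assigned to the ring on the thiocarbonyl carbon. Compound 4 is therefore expected near compound 1, with no step beyond the scatter: a number 3.6 percentage points higher from compound 1 to compound 4 (within the scatter). The estimate for compound 4 is 44%, ranging from 24% to 66%.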

Compound 4, percent growth inhibition at one concentration: 23.9%
For compound 4 the middle estimate is 20.1 percentage points above the measured one, outside the stated range (below it).
By their numbers in this assay, from the lowest: compound 4; then compounds 2 and 1 (each within the scatter of the next); then compound 3.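

With the core of compound 1 held constant, the group on the thiocarbonyl carbon proves to matter in this assay: the exchange of thiomorpholin-4-yl for piperidin-1-yl gives a number 16.5 percentage points lower from compound 1 to compound 4 (beyond the scatter). This is the first single change shown to go beyond the scatter, whereas the one earlier step, on the aromatic ring, did not. Nothing available accounts for this step. The compounds shown leave open where morpholin-4-yl or an open-chain dimethylamino group on the thiocarbonyl carbon would fall, and whether the same exchange has a similar effect without the methyl on the aromatic ring.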